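A cyclopropyl acyl cap on a weakly active scaffold

This account rests on a few compounds, and the source may have more. Where it says the series, first, only, none or still open, it means among the compounds named here.

Compound 1 `CN(C)CCNC(=O)c1nc(NC(=O)c2nc(NC(=O)CCl)cn2C)cn1C` carries a chloroacetyl cap on the shared core. In a functional assay on K562 cells (Homo sapiens) for inhibition (on this read-out lower numbers stand for stronger inhibition and higher numbers for weaker inhibition), compound 1 gives 350000 nM. Compound 2 `CN(C)CCNC(=O)c1nc(NC(=O)c2nc(NC(=O)C(Cl)Cl)cn2C)cn1C` bears the dichloromethyl version of that cap. In this assay compound 2 reaches only the assay limit of > 500000 nM, so no number is known for it. Among the compounds with values here, the one step measured between the two, an at least 1.4-fold higher number from compound 1 to compound 2 (0.15 log units; that floor lies within the scatter), is the sole guide, and it rests on (the limit of > 500000 nM in this assay, at which 1 of the 2 values shown sits). Compound 3 `CN(C)CCNC(=O)c1nc(NC(=O)c2nc(NC(=O)C3CC3)cn2C)cn1C` exchanges the dichloromethyl group: cyclopropyl in place of dichloromethyl on a carbonyl carbon. Within the data shown here, no measured step describes this exchange, so the step from compound 1 to compound 2 is the only size reference, and it marks no movement beyond the scatter. Compound 3 is expected to stay in the same weak region, with a step of a number no higher from compound 2 to compound 3 (the limit leaves the size open) that may again end at the limit. The estimate for compound 3 in this assay is 500000 nM, within 200000 nM to 2000000 nM.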

Compound 3, half-maximal inhibitory concentration: > 500000 nM
Compound 3: only a limit was reported; the forecaster's own chance of this, stated with the estimate: 70%; the middle value sits exactly at the limit.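

Swapping the halogenated cap for cyclopropyl, a ring of carbon only on the same carbonyl carbon, gave a second compound without a readable number in this assay. Against compound 1, the only compound here with a number, the record shows an at least 1.4-fold higher number from compound 1 to compound 3 (0.15 log units; that floor lies within the scatter), so a cap without chlorine has not been seen to differ from the chloroacetyl cap beyond the scatter. The step between compound 2 and compound 3 cannot be read, and the position has now yielded only one true number: the limit of > 500000 nM in this assay, at which 2 of the 3 values shown sit.

Going by these compounds, whether compound 2 and compound 3 differ at all remains open. Also open, on these data alone, is whether a different cap on this carbonyl carbon, such as an amine, a carboxylic acid or a longer alkyl chain, would give a value clearly apart from compound 1.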